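Closing a carbamate into an oxazolidinone on a shared core

The compounds below may be only part of what the source reports. "The series", "measured", "known", "first", "only" and "open" are said of these compounds alone.

Measured so far:
Compound 1 `COC(=O)N(Cc1ccc(F)cc1)c1c(N)nc(-c2nn(Cc3ccccc3F)c3ncccc23)nc1N`: 0.7 uM
Compound 2 `CC(C)OC(=O)Nc1c(N)nc(-c2nn(Cc3ccccc3F)c3ncccc23)nc1N`: 0.8 uM
Compound 3 `Nc1nc(-c2nn(Cc3ccccc3F)c3ncccc23)nc(N)c1NC(=O)OC1COC1`: 2.3 uM

These three compounds share one core and differ only in the group carried on the aromatic carbon. Going by the values given here, in an assay on cells for activation of Guanylate cyclase soluble subunit alpha-1 (Rattus norvegicus), read by cGMP accumulation and immunoassay, with a stated time of 10 min (on this read-out lower numbers stand for an effect already at smaller amounts and higher numbers for an effect only at larger amounts of compound), compound 3 gives the highest number of the three: the change from compound 2 to compound 3 gives a 2.9-fold higher number from compound 2 to compound 3 (0.46 log units; beyond the scatter), and compound 1 sits lower still at 0.7 uM, with no single-point step recorded between compound 1 and compound 3.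

Compound 4 `Nc1nc(-c2nn(Cc3ccccc3F)c3ncccc23)nc(N)c1N1C[C@@H](C(F)(F)F)OC1=O` carries 2-oxo-5-(trifluoromethyl)-1,3-oxazolidin-3-yl in place of (((oxetan-3-yl)oxy)carbonyl)amino on an aromatic carbon. Among the compounds with values here, no measured step covers this ring closure directly. Within the data shown here, the one step that touches the carbamate, a 2.9-fold higher number from compound 2 to compound 3 (0.46 log units; beyond the scatter), shows that varying the group on the oxygen can shift the number modestly, while compound 1 shows that a nitrogen without a hydrogen at this position is compatible with a low number. A small step down, within or near the scatter, is therefore expected, a 1.5-fold lower number from compound 3 to compound 4 (0.19 log units; within the scatter). Compound 4 is estimated at 1.5 uM, with a range from 0.4 uM to 5 uM.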

Compound 4, minimum effective concentration: 0.03 uM
Compound 4: middle estimate off by 50-fold (1.70 log units), on the high side; the whole stated range lies above it.
By their numbers in this assay, from the lowest: compound 4; then compounds 1 and 2 (each within the scatter of the next); then compound 3.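

The position carrying the carbamate turns out to be far more sensitive than the change on the oxygen suggested: in this assay, the closed ring gives a 77-fold lower number from compound 3 to compound 4 (1.88 log units; beyond the scatter), and measured against the isopropyl carbamate it still gives a 27-fold lower number from compound 2 to compound 4 (1.43 log units; beyond the scatter). Both steps are large, whereas changing the group on the oxygen moved the number only modestly. The entering group also has no hydrogen-bond donor, so a low number here does not need the carbamate's hydrogen on nitrogen, although nothing available explains the gain.

From the compounds shown here alone, the ring and the trifluoromethyl group arrive together in compound 4, so their separate contributions remain unknown, and a 2-oxo-1,3-oxazolidin-3-yl group carrying methyl in place of trifluoromethyl would help separate them. The importance of the defined stereocentre also stays open, as the mirror-image arrangement at that carbon is not among the compounds shown.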